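The source may hold more compounds than are shown below. What is called first, only, known or untested is meant among the compounds shown, and "the series" means these compounds.

Values in a functional assay on A2780 cells (Homo sapiens) for antiproliferative activity, read by sulforhodamine B assay, with a stated time of 48 h; on this read-out higher numbers stand for weaker inhibition of growth and lower numbers for stronger inhibition of growth:
- compound 1 `CC(C)(C)[Si](C)(C)O[C@@H]1CCCO[C@@H]1CO`: > 100000 nM (a limit)
- compound 2 `CC(C)(C)[Si](C)(C)O[C@@H]1CCCO[C@@H]1/C=C/C(=O)OCc1ccccc1`: 32000 nM
- compound 3 `CC(C)(C)[Si](C)(C)O[C@@H]1CCCO[C@@H]1/C=C\CO`: > 100000 nM (a limit)

Compound 3 gives no number: it stands at the limit of > 100000 nM in this assay, at which 2 of the 3 values shown sit. The next compound to be read is compound 4 `COC(=O)/C=C/[C@H]1OCCC[C@H]1O[Si](C)(C)C(C)(C)C`, not yet measured. The change is 2-(methoxycarbonyl)ethenyl in place of 3-hydroxyprop-1-en-1-yl on a saturated ring carbon.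

Among the compounds with values here, the only measured step between close neighbours is a step that the two limits leave unreadable from compound 1 to compound 3, so it offers no size to carry over. The nearest guide is a compound outside that step: compound 2 also carries an unsaturated ester and gives 32000 nM. Resting on that one number, a move towards stronger inhibition of growth is expected in this assay, of uncertain size, and the read-out may again be only a limit. The expected change is an at least 2.2-fold lower number from compound 3 to compound 4 (0.34 log units; beyond the scatter). Compound 4 is estimated at 45000 nM, with an expected range of 15000 nM to 100000 nM.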

Compound 4, concentration for 50% growth inhibition: 98000 nM
Estimate against measurement, compound 4: 2.2-fold (0.34 log units) below, and the stated range covers the measured number.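

In this assay the unsaturated ester side chain gets its first readable step, a 3.1-fold higher number from compound 2 to compound 4 (0.49 log units; beyond the scatter), so in this pair the phenyl of the ester goes with stronger inhibition of growth than hydrogen in its place. Against the two neighbours with a hydroxyl group only floors are available, an at least 1.0-fold lower number from compound 3 to compound 4 (0.00 log units; that floor lies within the scatter) and an at least 1.0-fold lower number from compound 1 to compound 4 (0.00 log units; that floor lies within the scatter), so 2-(methoxycarbonyl)ethenyl is not shown to differ from 3-hydroxyprop-1-en-1-yl or from hydroxymethyl. These steps remain floors because compound 1 and compound 3 each sit at a limit: the limit of > 100000 nM in this assay, at which 2 of the 4 values shown sit.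

As far as these compounds go, it remains open how an ethyl ester, a carboxylic acid or an amide at this place would read in this assay. From the compounds shown here alone, whether the step between phenyl and hydrogen holds on any other core also remains open.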